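The source may report more compounds than this note shows. Statements on the series, on what has been measured and on what is new or still open speak of the compounds shown alone.

Compound 1 `CCCOC(=O)C1=C(C)NC(C)=C(C(=O)OCC)C1c1[nH]c(CC)nc1Cl` and compound 2 `CCOC(=O)C1=C(C)NC(C)=C(C(=O)OC(C)C)C1c1[nH]c(CC)nc1Cl` share one core and differ only in an ester chain. In an assay on ileum for inhibition of Voltage-dependent L-type calcium channel subunit alpha-1C (Cavia porcellus) (on this read-out lower numbers stand for stronger inhibition and higher numbers for weaker inhibition), compound 1 gives 0.543 nM and compound 2 gives 0.564 nM; the step of a 1.0-fold higher number from compound 1 to compound 2 (0.02 log units; within the scatter) lies within the scatter, so compound 2 stands at the higher of two numbers that cannot be told apart. Compound 3 `CCOC(=O)C1=C(C)NC(C)=C(C(=O)OC(C)(C)C)C1c1[nH]c(CC)nc1Cl` carries methyl in place of hydrogen on a saturated chain carbon bound to an oxygen next to a carbonyl group and two saturated chain carbons. Among the compounds with values here, only the step from compound 1 to compound 2 bears on this change, and it showed no shift, so no step beyond the scatter is expected in this assay, with compound 3 estimated at 0.8 nM, between 0.3 nM and 2.5 nM, a step of a 1.4-fold higher number from compound 2 to compound 3 (0.15 log units; within the scatter).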

Compound 3, half-maximal inhibitory concentration: 99.8 nM
Beside the measured number, compound 3's estimate is 120-fold (2.10 log units) below it; the measured number lies above the stated range.
By their numbers in this assay, from the lowest: compounds 1 and 2 (each within the scatter of the next); then compound 3.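

Swapping propyl for isopropyl left the number unmoved, but a single added methyl, turning isopropyl into tert-butyl, gives a 180-fold higher number from compound 2 to compound 3 (2.25 log units; beyond the scatter) in this assay. Against the propyl ester, the tert-butyl ester gives a 180-fold higher number from compound 1 to compound 3 (2.26 log units; beyond the scatter). This ester chain therefore tolerates some changes, yet one more methyl on the isopropyl group is enough for a large loss of inhibition. No measurement shown accounts for this jump. On these data alone, it remains open whether a longer chain such as butyl, or a cyclopropyl ring on the same oxygen, would match compound 1 or compound 3.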